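Aryl amine to pyrrolidine on the shared core

The source may report more compounds than this note shows. Statements on the series, on what has been measured and on what is new or still open speak of the compounds shown alone.

Compound 3 `COc1ccccc1NC1=CC(=O)c2nc3n(c2C1=O)[C@H]1OC[C@@H](O)[C@H]1OC3` gives 1630 nM in a functional assay on MGC-803 cells (Homo sapiens) for inhibition, read by sulforhodamine B assay; a higher number here means a weaker inhibitor, a lower number a stronger inhibitor. Among the numbers in hand compound 3 holds the lowest one, but its nearest neighbour, compound 1 `O=C1C=C(Nc2cccc(Cl)c2)C(=O)c2c1nc1n2[C@H]2OC[C@@H](O)[C@H]2OC1` with 1770 nM in this assay, stands only a 1.1-fold lower number from compound 1 to compound 3 (0.04 log units; within the scatter) away, so the two cannot be ordered. Compound 2 `O=C1C=C(NC2CCCC2)C(=O)c2c1nc1n2[C@H]2OC[C@@H](O)[C@H]2OC1` is reported in this assay only as a limit, > 8000 nM.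

Compound 4 `O=C1C=C(N2CCCC2)C(=O)c2c1nc1n2[C@H]2OC[C@@H](O)[C@H]2OC1` differs from compound 3 in one place: pyrrolidin-1-yl in place of (2-methoxyphenyl)amino on a double-bonded ring carbon. Within the data shown here, two measured steps bear on this change, an at least 4.5-fold higher number from compound 1 to compound 2 (0.65 log units; beyond the scatter) and an at least 4.9-fold lower number from compound 2 to compound 3 (0.69 log units; beyond the scatter), each exchanging an aromatic ring on the amine nitrogen for a saturated five-membered ring or the reverse, and each beyond the scatter. Among the measured compounds shown here, the change to compound 4 again trades the aromatic ring for a saturated five-membered ring, here with the nitrogen made part of that ring; no measured pair covers that added difference. A weakening step is therefore expected, a 4.9-fold higher number from compound 3 to compound 4 (0.69 log units; beyond the scatter) being the estimate. Compound 4 is estimated at 8000 nM, in the range 3500 nM to 20000 nM, and a limit rather than a number is a real possibility because the limit of > 8000 nM in this assay, at which 1 of the 3 values shown sits, already marks the ceiling this series has reached.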

Compound 4, half-maximal inhibitory concentration: > 16000 nM
Compound 4 was reported as a limit; the forecaster's own chance of this, stated with the estimate: 55%; middle value at least 2.0-fold (0.30 log units) away from the limit.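

Compound 4 is reported in this assay only as a limit: the limit of > 16000 nM in this assay, at which 1 of the 4 values shown sits.

The readable steps into it are an at least 9.8-fold higher number from compound 3 to compound 4 (0.99 log units; beyond the scatter) and an at least 9.0-fold higher number from compound 1 to compound 4 (0.95 log units; beyond the scatter), both beyond the scatter, so on this double-bonded ring carbon a pyrrolidin-1-yl group, with no hydrogen-bond donor, falls well short of either aryl amine, as cyclopentylamino, which keeps its donor, already did. Among these compounds, compound 2 and compound 4 are both limits and the step between them cannot be read, so the effect of drawing the nitrogen into the saturated ring stays unresolved, and the series shows only that neither saturated five-membered ring group reaches a measured number in this assay.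

On these data alone, whether the aromatic ring itself or the amine hydrogen matters more remains open, and a benzylamino group, an N-methylanilino group or an open-chain diethylamino group would separate these two features. As far as these compounds go, how substituents on the aromatic ring act is also open, as compound 1 and compound 3 lie within the scatter of each other and carry different groups at different places on that ring.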